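Phenyl in Place of Hydrogen on a Saturated Ring Carbon

A few compounds are considered here, and "the series" means these few. Any claim that something is new, unique, unknown or untested is made for them only; others in the source may bear on it.

Measured so far:
compound 1 `CC(=O)c1cc(C(=O)c2ccccc2)c(=O)[nH]c1C` — 8.9%
compound 2 `O=C1CC(c2ccccc2)Cc2[nH]c(=O)c(C(=O)c3ccccc3)cc21` — 7.8%
compound 3 `O=C1CCCc2[nH]c(=O)c(S(=O)(=O)c3ccccc3)cc21` — 5.7%

Of the compounds shown here, three have been tested in an assay on isolated protein for inhibition of 3',5'-cyclic-AMP phosphodiesterase 4A (Cavia porcellus), read by cAMP accumulation, tested at 100 uM; on this read-out lower numbers stand for a weaker effect and higher numbers for a stronger effect at the one concentration tested. In this assay compound 1 gives 8.9%, compound 2 gives 7.8% and compound 3 gives 5.7%. Compound 3 holds the lowest of the three numbers, but its nearest neighbour, compound 2, lies within the scatter of it, and so does compound 1, the furthest of the three. None of the three can be called weaker or stronger than another on these numbers; all three sit low on the read-out.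

The unmeasured compound 4 `O=C1CC(c2ccccc2)Cc2[nH]c(=O)c(S(=O)(=O)c3ccccc3)cc21` differs from compound 3 in one place: phenyl in place of hydrogen on a saturated ring carbon. Among the measured compounds shown here, no pair among the measured compounds is recorded as a single step, so no measured step speaks directly to this change. What can be said is that compound 1 and compound 2, which also differ in the same region of the core, show numbers within the scatter of each other. In this assay, therefore, no step beyond the scatter is expected from compound 3 to compound 4, in either direction; the estimated step is a number 1.3 percentage points higher from compound 3 to compound 4 (within the scatter). Compound 4 is expected to give about 7%, in a range from 0% to 17%.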

Compound 4, a percentage reported as inhibition, at one concentration (the size of the read-out at that concentration, not a potency): 10.4%
The estimate for compound 4 lay 3.4 percentage points below the measured number; the range from low to high includes it.
By their numbers in this assay, from the lowest: compounds 3, 2, 1 and 4 (each within the scatter of the next).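

In this assay, phenyl in place of hydrogen on a saturated ring carbon now has a step of its own, a number 4.7 percentage points higher from compound 3 to compound 4 (within the scatter), so this change leaves the number within the scatter of the compound without the phenyl. Among the compounds shown here, the same result gives the first reading of a second change, phenylsulfonyl in place of benzoyl on an aromatic carbon, a number 2.6 percentage points higher from compound 2 to compound 4 (within the scatter), and with the phenyl in place on the saturated ring carbon, the two groups cannot be told apart on this read-out. Nothing among the data shown accounts for either step.

On these data alone, both steps rest on single-concentration numbers that all sit low on the read-out, so they give no direction, and it remains open whether any change at this position can carry the number beyond the scatter. Also open, as far as these compounds go, is how a methyl, a hydroxyl, an amine or a carboxylic acid would read in place of the phenyl on the saturated ring carbon, and whether a substituent on the phenyl itself would move the number at all.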